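The source may report more compounds than this note shows. Statements on the series, on what has been measured and on what is new or still open speak of the compounds shown alone.

Compound 1 `COc1ncnc2c1c(-c1ccccc1)cn2[C@@H]1O[C@H](CO)[C@@H](O)[C@H]1O` carries a methoxy group on the shared core. In a functional assay on HCT-116 cells (Homo sapiens), read by MTT assay, with a stated time of 72 h (a lower number here means a stronger inhibitor, a higher number a weaker inhibitor), compound 1 gives > 20000 nM, which is a limit of the assay and not a number. Compound 2 `CNc1ncnc2c1c(-c1ccccc1)cn2[C@@H]1O[C@H](CO)[C@@H](O)[C@H]1O` has methylamino in place of methoxy on an aromatic carbon. In this assay compound 2 gives > 20000 nM, again a limit. Compound 3 `CSc1ncnc2c1c(-c1ccccc1)cn2[C@@H]1O[C@H](CO)[C@@H](O)[C@H]1O` has methylsulfanyl in place of methoxy on an aromatic carbon. In this assay compound 3 gives > 20000 nM, also a limit. The steps a step that the two limits leave unreadable from compound 1 to compound 2, a step that the two limits leave unreadable from compound 1 to compound 3 and a step that the two limits leave unreadable from compound 2 to compound 3 are all unreadable in size because of the limit of > 20000 nM in this assay, at which 3 of the 3 values shown sit. Compound 2 thus stands at the limit with the other two, without a number of its own.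

Compound 4 `CNc1ncnc2c1c(-c1ccco1)cn2[C@@H]1O[C@H](CO)[C@@H](O)[C@H]1O` differs from compound 2 by furan-2-yl in place of phenyl on an aromatic carbon. Within the data shown here, no measured step bears on this change; the three measured changes concern methoxy, methylamino and methylsulfanyl, and none could be read. Nothing in the series points to a step beyond the scatter in this assay in either direction, so the step that the limit leaves unreadable from compound 2 to compound 4 is expected to stay small. Compound 4 is estimated at 25000 nM with a range from 8000 nM to 80000 nM, most likely reported again only as a limit.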

Compound 4, half-maximal inhibitory concentration: 230 nM
Compound 4: middle estimate off by 110-fold (2.04 log units), on the high side; the measured number lies below the stated range.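

The aromatic carbon that carries phenyl turns out to matter in this assay: furan-2-yl in place of phenyl gives an at least 86-fold lower number from compound 2 to compound 4 (1.93 log units; beyond the scatter), whereas the methoxy, methylamino and methylsulfanyl comparisons left every step unreadable. This step is a bound and not a full size, since compound 2 has only a limit to set against the measured value of compound 4: the limit of > 20000 nM in this assay, at which 3 of the 4 values shown sit. The change replaces a six-membered carbon ring with a five-membered ring holding one oxygen and one hydrogen-bond acceptor, and these features cannot be separated within this pair.

As far as these compounds go, whether furan-2-yl gives a comparable step alongside methoxy or methylsulfanyl on the shared core remains open. Also open, from the compounds shown here alone, is how this carbon responds to other groups, such as thiophen-2-yl, a pyridine ring or a longer alkyl chain.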